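A Butyl Chain Tried Against an Inert Pair

A few compounds are considered here, and "the series" means these few. Any claim that something is new, unique, unknown or untested is made for them only; others in the source may bear on it.

Compound 2 `CC(=O)c1ccc(NC(=O)CSC(=S)N[C@H]2CCOC2=O)cc1` stands at a limit: in a functional assay on SMMC-7721 cells (Homo sapiens) for cytotoxicity, read by MTT assay, with a stated time of 72 h (on this read-out higher numbers stand for weaker inhibition and lower numbers for stronger inhibition), compound 2 gives > 128000 nM, which is a limit of the assay and not a number. Compound 1 `COc1ccc(NC(=O)CSC(=S)N[C@H]2CCOC2=O)cc1` likewise reaches only a limit, giving > 128000 nM in this assay. Among the compounds with values here, the one measured step, a step that the two limits leave unreadable from compound 1 to compound 2, cannot be read because both values rest on (the limit of > 128000 nM in this assay, at which 2 of the 2 values shown sit). Compound 3 `CCCCc1ccc(NC(=O)CSC(=S)N[C@H]2CCOC2=O)cc1` differs from compound 2 by butyl in place of acetyl on an aromatic carbon. Within the data shown here, no measured step tells how such a change acts here. Compound 3 is expected to sit at the same limit, estimated at 200000 nM with a range from 60000 nM to 1000000 nM. This would mean an expected step that the limit leaves unreadable from compound 2 to compound 3.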

Compound 3, half-maximal inhibitory concentration: 27300 nM
Compound 3: the middle estimate sits 7.3-fold (0.86 log units) above what was measured; measured number outside the range, below it.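

In this assay, the group on the aromatic carbon para to a large group can now be seen to move the read-out: butyl in place of acetyl gives an at least 4.6-fold lower number from compound 2 to compound 3 (0.67 log units; beyond the scatter), and butyl in place of methoxy gives an at least 4.6-fold lower number from compound 1 to compound 3 (0.67 log units; beyond the scatter). Compound 3 is the only one of the three compounds shown that gives a number and not a limit. The step between the other two compounds still cannot be read, and both new steps give only a minimum size: the limit of > 128000 nM in this assay, at which 2 of the 3 values shown sit.

From the compounds shown here alone, whether a longer chain, such as hexyl, would lower the number further remains open. So does the effect of an amine or a carboxylic acid at this place.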